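The source may report more compounds than this note shows. Statements on the series, on what has been measured and on what is new or still open speak of the compounds shown alone.

Measured compounds in a functional assay on MCF7 cells (Homo sapiens) for antiproliferative activity, read by MTT assay, with a stated time of 48 h; a lower number here means a stronger inhibitor, a higher number a weaker inhibitor:
compound 1 `Cc1ccccc1-n1nncc1CN1C(=O)C2(C(C#N)=C(N)Oc3c2c2nc4ccccc4nc2c2ccccc32)c2ccccc21`: > 50000 nM.
compound 2 `CC(=O)Nc1ccc(-n2nncc2CN2C(=O)C3(C(C#N)=C(N)Oc4c3c3nc5ccccc5nc3c3ccccc43)c3ccccc32)cc1`: > 50000 nM.
compound 3 `CCc1ccccc1-n1nncc1CN1C(=O)C2(C(C#N)=C(N)Oc3c(N)cc4nc5ccccc5nc4c32)c2ccccc21`: 24600 nM.

The value of compound 1 is a limit of the assay, not a number. The value of compound 2 is likewise a limit. Compound 3 therefore stands as the only number shown in this assay; the other two values sit at the limit of > 50000 nM in this assay, at which 2 of the 3 values shown sit. Compound 4 `N#CC1=C(N)Oc2c(N)cc3nc4ccccc4nc3c2C12C(=O)N(Cc1cnnn1-c1cc(Cl)ccc1Cl)c1ccccc12` carries 2,5-dichlorophenyl in place of 2-ethylphenyl on an aromatic nitrogen. Within the data shown here, the only step between measured compounds, a step that the two limits leave unreadable from compound 1 to compound 2, does not concern this exchange and cannot be read; no measured step bears on it. With no readable step to lean on, the estimated step of a 1.0-fold higher number from compound 3 to compound 4 (0.01 log units; within the scatter) for compound 4 is set at none beyond the scatter, and a limit rather than a number remains a real possibility. Compound 4 is thus expected to give 25000 nM in this assay, within 8000 nM to 80000 nM.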

Compound 4, half-maximal inhibitory concentration: 33200 nM
Estimate against measurement, compound 4: 1.3-fold (0.12 log units) below; the measured number falls inside the stated range.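

In this assay, 2,5-dichlorophenyl in place of 2-ethylphenyl on the aromatic nitrogen gives a 1.3-fold higher number from compound 3 to compound 4 (0.13 log units; within the scatter). Among these compounds, this is the first readable step at this position, and it shows that an exchange of ethyl for two chlorines on the phenyl ring leaves a measurable number on this core. The earlier step at this position cannot be read, as compound 1 and compound 2 both stand at a limit of the assay: the limit of > 50000 nM in this assay, at which 2 of the 4 values shown sit.

Going by these compounds, whether any group at this position gives a step beyond the scatter stays open. An amine or a carboxylic acid on the phenyl ring, or a longer chain in place of ethyl, would test this.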